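Ethyl to Methylsulfanyl: Expected Clearance in Mouse Microsomes

The source may report more compounds than this note shows. Statements on the series, on what has been measured and on what is new or still open speak of the compounds shown alone.

Compound 1 `Cc1cc(Nc2ccc(S(F)(F)(F)(F)F)cc2)n2nc(C3CC3)nc2n1`: 12.6 mL.min-1.g-1
Compound 2 `CCc1nc2nc(C)cc(Nc3ccc(C(F)(F)F)cc3)n2n1`: 14.4 mL.min-1.g-1
Compound 3 `Cc1cc(Nc2ccc(Cl)cc2)n2nc(C(C)C)nc2n1`: 158 mL.min-1.g-1

In an in vitro ADME assay on microsomes from liver (Mus musculus) for metabolic stability (a lower number here means slower removal, a higher number faster removal of the compound), compound 2 gives 14.4 mL.min-1.g-1, the second highest of the three numbers. Compound 1, at 12.6 mL.min-1.g-1, sits within the usual scatter of compound 2, so the two cannot be told apart. Compound 3, at 158 mL.min-1.g-1, lies far above compound 2, well beyond the scatter.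

Compound 4 `CSc1nc2nc(C)cc(Nc3ccc(C(F)(F)F)cc3)n2n1` differs from compound 2 in one place: methylsulfanyl in place of ethyl on an aromatic carbon. Among the measured compounds shown here, no pair of measured compounds shows this change, so the expectation rests on the structures alone. A moderate rise in clearance is expected, with the step from compound 2 to compound 4 estimated at a 1.9-fold higher number from compound 2 to compound 4 (0.29 log units; within the scatter). Compound 4 is therefore estimated at 28 mL.min-1.g-1, within a range from 10 mL.min-1.g-1 to 75 mL.min-1.g-1.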

Compound 4, intrinsic clearance in microsomes: 76.9 mL.min-1.g-1
Estimate against measurement, compound 4: 2.7-fold (0.44 log units) below, and the stated range ends below it.
By their numbers in this assay, from the lowest: compounds 1 and 2 (each within the scatter of the next); then compound 4; then compound 3.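

Methylsulfanyl in place of ethyl on this aromatic carbon, between two ring nitrogen atoms, gives a 5.3-fold higher number from compound 2 to compound 4 (0.73 log units; beyond the scatter) in this assay. Among the compounds shown here, the earlier compounds differ in more than one place, so only this pair shows that clearance responds to this one change, even though both groups have the same number of heavy atoms. No measurement shown here explains the rise.

From the compounds shown here alone, whether methoxy or a longer chain such as propyl here would sit nearer compound 2 or compound 4 stays open. So does whether this change gives a similar step alongside the chloro or pentafluorosulfanyl groups.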